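From 4-methylphenyl to 4-chlorophenyl: working notes on the series

A few compounds are considered here, and "the series" means these few. Any claim that something is new, unique, unknown or untested is made for them only; others in the source may bear on it.

Measured so far in a functional assay on B16-F10 cells (Mus musculus) for cytotoxicity (a higher number here means a weaker inhibitor, a lower number a stronger inhibitor), for three compounds:
- compound 1 `O=c1oc2ccccc2c2nc3c(ccc4cc[nH]c43)c(-c3ccc(C(F)(F)F)cc3)c12` gives 70700 nM
- compound 2 `O=c1oc2ccccc2c2nc3c(ccc4cc[nH]c43)c(-c3ccc(O)cc3)c12` gives 70700 nM
- compound 3 `Cc1ccc(-c2c3ccc4cc[nH]c4c3nc3c2c(=O)oc2ccccc23)cc1` gives 70700 nM

Compound 3 stands level with compound 1 and compound 2 in this assay at the digits available, so none of the three leads.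

The next compound is compound 4 `O=c1oc2ccccc2c2nc3c(ccc4cc[nH]c43)c(-c3ccc(Cl)cc3)c12` with chloro in place of methyl on an aromatic carbon, para to a large group chloro in place of methyl on an aromatic carbon and the same difference reads 4-methylphenyl to 4-chlorophenyl.

Going by the values given here, three measured steps bear on this change, all on the same aromatic carbon. Hydroxy in place of trifluoromethyl gave no change at the digits printed from compound 1 to compound 2 (within the scatter) and methyl in place of trifluoromethyl gave no change at the digits printed from compound 1 to compound 3 (within the scatter) while methyl in place of hydroxy gave no change at the digits printed from compound 2 to compound 3 (within the scatter) in the same read-out. Among the compounds with values here, no chloro compound has been measured yet, so these steps are the only guide. None of them goes beyond the scatter, so no step beyond the scatter and no direction is expected in this assay for this swap.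

This expectation rests on compound 3 at 70700 nM and on the three steps above. The estimated step is no change at the digits printed from compound 3 to compound 4 (within the scatter) on this reasoning. Compound 4 is expected at about 70700 nM with an estimated range from 35000 nM to 100000 nM in this assay for now.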

Compound 4, half-maximal inhibitory concentration: 70700 nM
Estimate against measurement, compound 4: no gap at the digits printed; low and high end bracket the measured number.
By their numbers in this assay, from the lowest: compounds 1, 2, 3 and 4 (each within the scatter of the next).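

In this assay chloro in place of methyl gives no change at the digits printed from compound 3 to compound 4 (within the scatter) while chloro in place of hydroxy gives no change at the digits printed from compound 2 to compound 4 (within the scatter) and chloro in place of trifluoromethyl gives no change at the digits printed from compound 1 to compound 4 (within the scatter) on the same aromatic carbon. The earlier compounds shown here covered trifluoromethyl, hydroxy and methyl at this carbon; with chloro added, all four groups on the six-membered aromatic ring read alike, and compound 4 at 70700 nM opens no step beyond the scatter among compound 1, compound 2, compound 3 and compound 4. No measurement in hand explains this flat reading.

The compounds shown leave open whether an amine, a carboxylic acid or a longer chain such as butyl on this carbon would move the number in this assay at all. They also leave open whether a change elsewhere on this aromatic ring or on the shared core would give a step beyond the scatter, since every compound here differs only at this one carbon.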